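Trimming the amide acyl chain in a type-2 receptor series

The compounds below may be only part of what the source reports. "The series", "measured", "known", "first", "only" and "open" are said of these compounds alone.

Compound 1 `CCCC(=O)N(CCC(=O)c1c(CC)nc(CCC)n1Cc1ccc(-c2ccccc2S(=O)(=O)NC(=O)OCCC(C)C)cc1F)c1ccccc1` gives 0.15 nM in an assay on isolated protein for inhibition of Type-2 angiotensin II receptor (Rattus norvegicus); a lower number here means a stronger inhibitor, a higher number a weaker inhibitor. Compound 2 `CCCc1nc(CC)c(C(=O)CCN(C(=O)CC)c2cccnc2)n1Cc1ccc(-c2ccccc2S(=O)(=O)NC(=O)OCCC(C)C)cc1F` gives 0.49 nM in this assay, and so stands with the highest number of the two measured compounds, its nearest neighbour being compound 1 at a 3.3-fold higher number from compound 1 to compound 2 (0.51 log units; beyond the scatter). Compound 3 `CCCc1nc(CC)c(C(=O)CCN(C(C)=O)c2cccnc2)n1Cc1ccc(-c2ccccc2S(=O)(=O)NC(=O)OCCC(C)C)cc1F` differs from compound 2 by hydrogen in place of methyl on a saturated chain carbon bound to a carbonyl carbon. Going by the values given here, the only measured step, from compound 1 to compound 2, concerns the aryl group on the amide nitrogen and not the acyl chain, so nothing measured bears directly on the change to compound 3. Without a precedent for shortening the acyl chain, the step is expected to stay small, most likely within the scatter or a little toward a higher number, giving compound 3 an estimated 0.7 nM (range 0.3 nM to 1.6 nM), which is expected to amount to a 1.4-fold higher number from compound 2 to compound 3 (0.15 log units; within the scatter).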

Compound 3, half-maximal inhibitory concentration: 3 nM
Beside the measured number, compound 3's estimate is 4.3-fold (0.63 log units) below it; the whole stated range lies below it.
By their numbers in this assay, from the lowest: compound 1; then compound 2; then compound 3.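

In this assay, trimming propanoyl to acetyl on the pyridin-3-yl amide gives a 6.1-fold higher number from compound 2 to compound 3 (0.79 log units; beyond the scatter), which shows that the acyl chain is not a silent position: the loss of a single methyl here moves the number beyond the scatter. The acyl change and the aryl change both run toward a higher number, and the full replacement of phenyl(propylcarbonyl)amino by acetyl(pyridin-3-yl)amino amounts to a 20-fold higher number from compound 1 to compound 3 (1.30 log units; beyond the scatter). No measurement available here accounts for this sensitivity to chain length.

Still open, going by these compounds, is whether the trend continues on the pyridin-3-yl amide with a longer chain such as butanoyl or pentanoyl, or whether it reverses there. On these data alone, it is also open whether the acetyl step would be of similar size on the phenyl amide, or with a formyl group in its place.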